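This account rests on a few compounds, and the source may have more. Where it says the series, first, only, none or still open, it means among the compounds named here.

In an assay on isolated protein for binding affinity to histamine H2 receptor (Homo sapiens) (a higher number here means a weaker inhibitor, a lower number a stronger inhibitor), compound 1 `CCCCCC(=O)c1ccc(OCCCN2CCNCC2)cc1` gives 14500 nM, compound 2 `CCCCCC(=O)c1ccc(OCCCN2CCN(C(=O)N3CCOCC3)CC2)cc1` gives 17800 nM, and compound 3 `CCCCCC(=O)c1ccc(OCCCN2CCN(C(=O)C3CCC3)CC2)cc1` gives 10200 nM, the lowest of the three numbers, though each step to it lies within the scatter: a 1.4-fold lower number from compound 1 to compound 3 (0.15 log units; within the scatter) and a 1.7-fold lower number from compound 2 to compound 3 (0.24 log units; within the scatter). Compound 4 `CCCCCC(=O)c1ccc(OCCCN2CCN(CC3CC3)CC2)cc1` carries cyclopropylmethyl in place of cyclobutylcarbonyl on an amine nitrogen in a ring. For the measured compounds named here, no measured step removes the carbonyl from this ring nitrogen; the nearest guides are the steps that add an acyl group, a 1.2-fold higher number from compound 1 to compound 2 (0.09 log units; within the scatter) and a 1.4-fold lower number from compound 1 to compound 3 (0.15 log units; within the scatter), both within the scatter, and the exchange of one acyl substituent for another, a 1.7-fold lower number from compound 2 to compound 3 (0.24 log units; within the scatter), also within the scatter. Compound 4 is therefore expected to show a step of about a 1.3-fold lower number from compound 3 to compound 4 (0.11 log units; within the scatter) in this assay, not beyond the scatter. Compound 4 is estimated at 8000 nM, with a range from 2500 nM to 25000 nM.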

Compound 4, inhibition constant: 18600 nM
The estimate for compound 4 lay 2.3-fold (0.37 log units) below the measured number, within the range that was stated.
By their numbers in this assay, from the lowest: compounds 3, 1, 2 and 4 (each within the scatter of the next).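

Compound 4 shows that cyclopropylmethyl, which carries no carbonyl, can stand on this amine nitrogen in a ring while this assay stays within the scatter of all three earlier compounds (a 1.8-fold higher number from compound 3 to compound 4 (0.26 log units; within the scatter); a 1.0-fold higher number from compound 2 to compound 4 (0.02 log units; within the scatter); a 1.3-fold higher number from compound 1 to compound 4 (0.11 log units; within the scatter)). Among the compounds shown, this assay therefore does not separate hydrogen, the two carbonyl-linked groups and cyclopropylmethyl at this position. Nothing measured here offers a reason for these small steps.

Going by these compounds, whether a benzyl group or a longer alkyl chain on this nitrogen would give a step beyond the scatter remains open.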